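The source may hold more compounds than are shown below. What is called first, only, known or untested is meant among the compounds shown, and "the series" means these compounds.

Compound 1, `O=C1C(=O)N(CCCNc2ccnc3cc(Cl)ccc23)c2cc(Cl)ccc21`, and compound 2, `O=C1C(=O)N(CCCNc2ccnc3cc(Cl)ccc23)c2cc(Br)ccc21`, share one core, and compound 3, `O=C1C(=O)N(CCCNc2ccnc3cc(C(F)(F)F)ccc23)c2cccc(Cl)c21`, carries a different one; how the two cores differ is not broken down here. All three were tested in a functional assay on MCF7 cells (Homo sapiens) for antiproliferative activity, read by sulforhodamine B assay, with a stated time of 48 h; on this read-out higher numbers stand for weaker inhibition of growth and lower numbers for stronger inhibition of growth. Compound 1 gives 7360 nM, compound 2 gives 16600 nM, and compound 3 gives 18800 nM. The change from compound 1 to compound 2 is bromo in place of chloro on an aromatic carbon, and it produced a 2.3-fold higher number from compound 1 to compound 2 (0.35 log units; beyond the scatter).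

Compound 4, `O=C1C(=O)N(CCCNc2ccnc3cc(C(F)(F)F)ccc23)c2cccc(Br)c21`, has not yet been measured. It differs from compound 3 by bromo in place of chloro on an aromatic carbon. Going by the values given here, this is the same kind of change as the one from compound 1 to compound 2, though the surroundings differ: in compound 1 the site is meta to a fused ring and para to a fused ring, while in compound 3 it is ortho to a fused ring and meta to a fused ring.

Resting on a single earlier step, the exchange is expected to move compound 4 by a 1.9-fold higher number from compound 3 to compound 4 (0.28 log units; within the scatter) in this assay, because that step gave a 2.3-fold higher number from compound 1 to compound 2 (0.35 log units; beyond the scatter). Compound 4 is therefore estimated at 36000 nM, with a plausible span from 15000 nM to 85000 nM.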

Compound 4, concentration for 50% growth inhibition: 34400 nM
Compound 4: the middle estimate sits 1.0-fold (0.02 log units) above what was measured; the measured number falls inside the stated range.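

In this assay, the exchange of chloro for bromo on the core of compound 3, at the site ortho to a fused ring and meta to a fused ring, gives a 1.8-fold higher number from compound 3 to compound 4 (0.26 log units; within the scatter). Set beside the earlier step, this indicates that the exchange carried over between the two cores with no detectable difference in size: the same change on two cores in this assay, a 2.3-fold higher number (0.35 log units; beyond the scatter) from compound 1 to compound 2 and a 1.8-fold higher number (0.26 log units; within the scatter) from compound 3 to compound 4, 1.2-fold (0.09 log units) apart, within the scatter of two such steps. Going by these compounds alone, this agreement rests on only two pairs, however, and the step on the core of compound 3 does not stand clear of the scatter by itself, so it neither establishes a general rule for the series nor explains why the numbers move as they do.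

The compounds shown leave open how fluoro, iodo or a methoxy group would behave at these sites, and whether the step would persist with a longer chain joining the two parts of the molecule. They also leave open whether the same exchange would give a similar step on any other core in the series.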